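The source may report more compounds than this note shows. Statements on the series, on what has been measured and on what is new or still open speak of the compounds shown alone.

Measured so far in this study:

compound 1, `Cc1c(C(=O)N/N=C\c2cc(F)ccc2O)oc2cccc(O)c12`, 5230 nM
compound 2, `Cc1c(C(=O)N/N=C\c2ccc(O)c(O)c2O)oc2cccc(O)c12`, 18100 nM

Both compounds were tested in a functional assay on MGC-803 cells (Homo sapiens) for inhibition, read by MTT assay; a higher number here means a weaker inhibitor, a lower number a stronger inhibitor. Compound 1 gives the lower of the two numbers, and the gap from compound 1 up to compound 2 lies beyond the usual scatter of repeated measurements, so compound 1 stands as the stronger inhibitor of the pair on the numbers shown.

The next compound, compound 3, `Cc1c(C(=O)N/N=C\c2cc(Cl)ccc2O)oc2cccc(O)c12`, is built from compound 1 by a single change: chloro in place of fluoro on an aromatic carbon. Put more simply, the 5-fluoro-2-hydroxyphenyl part of compound 1 becomes a 5-chloro-2-hydroxyphenyl part in compound 3. Going by the values given here, no measured pair in this set shows what swapping one halogen for another does here, so there is no directly comparable step to lean on. With that caveat, compound 3 is expected to land close to compound 1, with a step of a 1.3-fold lower number from compound 1 to compound 3 (0.12 log units; within the scatter) in this assay that most likely stays within the scatter, perhaps leaning toward a slightly lower number. The estimate for compound 3 is 4000 nM, with a plausible range from 1500 nM to 12000 nM.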

Compound 3, half-maximal inhibitory concentration: 4160 nM
Compound 3: middle estimate off by 1.0-fold (0.02 log units), on the low side, within the range that was stated.
By their numbers in this assay, from the lowest: compounds 3 and 1 (each within the scatter of the next); then compound 2.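

In this assay, exchanging fluoro for chloro on this aromatic carbon, para to a hydroxy group, gives a 1.3-fold lower number from compound 1 to compound 3 (0.10 log units; within the scatter), so the two halogens cannot be told apart at this position. The position therefore accepts either of these two groups without a readable change in the number, at least in this one pair of compounds. Compound 1 and compound 2 differ in more than one place, so they could not isolate the effect of a single group here, and nothing available explains why this exchange leaves the number where it is.

The compounds shown leave open whether this tolerance reaches beyond fluoro and chloro, for example to bromo, to a methoxy group or to an amine, any of which could move the number well away from that of compound 1 or leave it in the same place. Also open, as far as these compounds go, is whether a plain hydrogen at this position would do as well as either halogen, which would show whether a substituent here matters at all in this assay.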